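A few compounds are considered here, and "the series" means these few. Any claim that something is new, unique, unknown or untested is made for them only; others in the source may bear on it.

Working notes on the series. Compound 1 `COc1ccc(/C=C/c2cc(=O)cco2)cc1` and compound 2 `COc1ccc(/C=C/c2cc(=O)cco2)cc1OC` share one core; compound 3 `COc1ccc(/C=C/C2CC=CC(=O)O2)cc1` and the unmeasured compound 4 `COc1ccc(/C=C/C2CC=CC(=O)O2)cc1OC` share another. The difference between the two cores is not broken down here.

In a functional assay on NCI-H460 cells (Homo sapiens) for inhibition, read by sulforhodamine B assay, with a stated time of 48 h (a higher number here means a weaker inhibitor of growth, a lower number a stronger inhibitor of growth), compound 1 gives 606 uM, and compound 2 gives 546 uM. The change between them, (methoxy in place of hydrogen on an aromatic carbon), produced a 1.1-fold lower number from compound 1 to compound 2 (0.05 log units; within the scatter). Compound 3 gives 28.3 uM in this assay, the lowest of the three measured numbers; its nearest neighbour is compound 2 and its furthest is compound 1, and both gaps lie beyond the scatter, so the second core is clearly the stronger of the two in this assay.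

Compound 4 carries the same change on the second core: methoxy in place of hydrogen on an aromatic carbon. The surroundings of the place are described in the same words for both pairs, so this is the same change, now made once more; among the compounds shown it occurs twice in all. Set beside the earlier step, the step to compound 4 is expected to be small, a 1.1-fold lower number from compound 3 to compound 4 (0.05 log units; within the scatter), because a 1.1-fold lower number from compound 1 to compound 2 (0.05 log units; within the scatter) stayed within the scatter. Within the data shown here, only one prior instance of the change exists, and whether the second core answers it in the same way is untested, so the range is kept wide. Compound 4 is therefore estimated at 25 uM in this assay, expected to fall between 10 uM and 70 uM.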

Compound 4, concentration for growth inhibition (reported as GI): 14.6 uM
Estimate against measurement, compound 4: 1.7-fold (0.23 log units) above; the range from low to high includes it.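

Methoxy in place of hydrogen on an aromatic carbon, here ortho to a methoxy group, gives in this assay a 1.9-fold lower number from compound 3 to compound 4 (0.29 log units; within the scatter) on the second core. Set beside the same change on the first core, the two steps do not differ: the same change on two cores in this assay, a 1.1-fold lower number (0.05 log units; within the scatter) from compound 1 to compound 2 and a 1.9-fold lower number (0.29 log units; within the scatter) from compound 3 to compound 4, 1.7-fold (0.24 log units) apart, within the scatter of two such steps.

On these two cores, then, the change carries over with no step beyond the scatter on either core and no gap beyond the scatter between the steps, but two pairs show neither that the change has a real effect on either core nor that the same would hold on any other core, and the small difference between the two steps cannot be read as a difference between the cores.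

The compounds shown leave open whether another group in the same place, such as hydroxy, an amine, a carboxylic acid or a longer chain such as ethoxy, would give a step beyond the scatter on either core, and whether such a step would carry from one core to the other. They also leave open how methoxy behaves elsewhere on the aromatic ring, and how this change reads on other cell lines.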